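The source may hold more compounds than are shown below. What is called first, only, known or untested is meant among the compounds shown, and "the series" means these compounds.

The measured compounds:
compound 1, `CCCCCCOc1cc(OC)c(Br)cc1C(C)=O`, 53100000 nM
compound 2, `CCCCCCCCOc1cc(OC)c(Br)cc1C(C)=O`, 38100000 nM
compound 3, `CCCCCCCCCCCCCCOc1cc(OC)c(Br)cc1C(C)=O`, 13200000 nM

All three values come from a functional assay, with a stated time of 10 min; a higher number here means a weaker inhibitor, a lower number a stronger inhibitor. The compounds share one core and differ only in the chain on an oxygen on the aromatic ring. Compound 2 differs from compound 1 by ethyl in place of hydrogen on a saturated chain carbon, six bonds along the chain from an oxygen on an aromatic ring, a step of a 1.4-fold lower number from compound 1 to compound 2 (0.14 log units; within the scatter). Compound 3 differs from compound 1 by octyl in place of hydrogen on a saturated chain carbon, six bonds along the chain from an oxygen on an aromatic ring, a step of a 4.0-fold lower number from compound 1 to compound 3 (0.60 log units; beyond the scatter); from compound 2 the step is a 2.9-fold lower number from compound 2 to compound 3 (0.46 log units; beyond the scatter). Compound 4, `CCCCCCCCCCCCCCCCOc1cc(OC)c(Br)cc1C(C)=O`, is not yet measured and differs from compound 3 by ethyl in place of hydrogen on a saturated chain carbon, ten or more bonds along the chain from an oxygen on an aromatic ring. This is the same kind of change as from compound 1 to compound 2, but it sits at a different place along the chain. Because the earlier step of a 1.4-fold lower number from compound 1 to compound 2 (0.14 log units; within the scatter) was within the scatter, compound 4 is expected to give only a small step, a 1.3-fold lower number from compound 3 to compound 4 (0.12 log units; within the scatter), with an estimated 10000000 nM.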

Compound 4, half-maximal inhibitory concentration: 100000 nM
Estimate against measurement, compound 4: 100-fold (2.00 log units) above; the measured number lies below the stated range.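

In this assay the ethyl change does not carry over from the shorter chain to the longer one, giving a 130-fold lower number from compound 3 to compound 4 (2.12 log units; beyond the scatter) against a far smaller earlier step: the same change on two cores in this assay, a 1.4-fold lower number (0.14 log units; within the scatter) from compound 1 to compound 2 and a 130-fold lower number (2.12 log units; beyond the scatter) from compound 3 to compound 4, 95-fold (1.98 log units) apart, beyond the scatter of two such steps.
The octyl change, with a 380-fold lower number from compound 2 to compound 4 (2.58 log units; beyond the scatter), also differs from its earlier counterpart: the same change on two cores in this assay, a 4.0-fold lower number (0.60 log units; beyond the scatter) from compound 1 to compound 3 and a 380-fold lower number (2.58 log units; beyond the scatter) from compound 2 to compound 4, 95-fold (1.98 log units) apart, beyond the scatter of two such steps.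
Both comparisons rest on the same four compounds, so they show that the size of a step here depends on the chain it is made on, but they do not explain why.

As far as these compounds go, whether a longer chain would continue this trend remains open. So does whether a chain ending in a carboxylic acid or an amine would behave like these.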